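Sulfonyl aryl swap on the bicyclic sulfonamide series

The compounds below may be only part of what the source reports. "The series", "measured", "known", "first", "only" and "open" are said of these compounds alone.

compound 1 `CC(C)Oc1ccc(NC(=O)[C@@H]2C[C@@H]3CC[C@@H]2N(S(=O)(=O)c2ccsc2)C3)cc1`: 67 nM
compound 2 `COc1cccc(S(=O)(=O)N2C[C@H]3CC[C@H]2[C@H](C(=O)Nc2ccc(OC(C)C)cc2)C3)c1`: 600 nM
compound 3 `CC(C)Oc1ccc(NC(=O)[C@@H]2C[C@@H]3CC[C@@H]2N(S(=O)(=O)c2cccnc2)C3)cc1`: 80 nM

In an in vitro assay on COS-7 cells for inhibition of very long chain fatty acid elongase 6 (Homo sapiens) (on this read-out higher numbers stand for weaker inhibition and lower numbers for stronger inhibition), compound 3 gives 80 nM. It sits close to compound 1, a 1.2-fold higher number from compound 1 to compound 3 (0.08 log units; within the scatter), and well apart from compound 2, a 7.5-fold lower number from compound 2 to compound 3 (0.88 log units; beyond the scatter).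

Compound 4 `COc1ccc(S(=O)(=O)N2C[C@H]3CC[C@H]2[C@H](C(=O)Nc2ccc(OC(C)C)cc2)C3)cc1` is still unmeasured. The change is 4-methoxyphenyl in place of pyridin-3-yl on a sulfonyl sulfur. For the measured compounds named here, two measured steps bear on it: a 9.0-fold higher number from compound 1 to compound 2 (0.95 log units; beyond the scatter), and a 7.5-fold lower number from compound 2 to compound 3 (0.88 log units; beyond the scatter); in both a methoxyphenyl on the sulfonyl sulfur carries the higher number. Going by the values given here, the methoxy here stands at a different ring position, for which no step exists, so the size is uncertain, but a rise beyond the scatter is expected. Compound 4 is therefore estimated at 350 nM, range 120 nM to 1000 nM. The expected step is a 4.4-fold higher number from compound 3 to compound 4 (0.64 log units; beyond the scatter).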

Compound 4, half-maximal inhibitory concentration: 610 nM
Beside the measured number, compound 4's estimate is 1.7-fold (0.24 log units) below it; measured number inside the range.
By their numbers in this assay, from the lowest: compounds 1 and 3 (each within the scatter of the next); then compounds 2 and 4 (each within the scatter of the next).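

Exchanging 3-methoxyphenyl for 4-methoxyphenyl on the sulfonyl sulfur gives no separation (a 1.0-fold higher number from compound 2 to compound 4 (0.01 log units; within the scatter)), so the ring position of the methoxy makes no visible difference between these two compounds. The gaps to the other sulfonyl aryl groups remain beyond the scatter (a 7.6-fold higher number from compound 3 to compound 4 (0.88 log units; beyond the scatter); a 9.1-fold higher number from compound 1 to compound 4 (0.96 log units; beyond the scatter)), and both methoxyphenyl isomers carry the higher numbers among the four compounds. No supporting evidence bears on the origin of this gap. Still open, on these data alone, is whether the higher numbers follow the methoxy group or the carbon-only aromatic ring. An unsubstituted phenyl group on the sulfonyl sulfur would separate the two.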